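Aryl amine variation in a dihydrofolate reductase inhibitor series

This account rests on a few compounds, and the source may have more. Where it says the series, first, only, none or still open, it means among the compounds named here.

Measured so far in an assay on isolated protein for inhibition of Dihydrofolate reductase (Homo sapiens), read by spectrophotometry; on this read-out higher numbers stand for weaker inhibition and lower numbers for stronger inhibition:

compound 1 `COc1cc(N(C)Cc2nc3cc(C(F)(F)F)ccc3nc2-c2ccccc2)cc(OC)c1OC`: 5000 nM
compound 2 `C#CCN(Cc1nc2cc(C(F)(F)F)ccc2nc1-c1ccccc1)c1ccc(Cl)cc1`: 4000 nM
compound 3 `C#CCN(Cc1nc2cc(C(F)(F)F)ccc2nc1-c1ccccc1)c1ccc(OC)c(OC)c1`: 3000 nM

Compound 3 gives the lowest of the three numbers, but its gap to compound 2, the nearest, and to compound 1, the furthest, are both within the usual scatter, so the three compounds are not separated by these data. Among the measured compounds shown here, the only single-place step among them, a 1.3-fold lower number from compound 2 to compound 3 (0.12 log units; within the scatter), is likewise within the scatter.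

Compound 4 `C#CCN(Cc1nc2cc(C(F)(F)F)ccc2nc1-c1ccccc1)c1cc(OC)c(OC)c(OC)c1` differs from compound 3 by methoxy in place of hydrogen on an aromatic carbon. For the measured compounds named here, compound 1 also carries the trimethoxyphenyl group, but with a methyl rather than a propargyl on the amine nitrogen, so no single-place step connects it to compound 3; its value and that of compound 3 sit within the scatter of each other. Nothing measured here therefore points to a move beyond the scatter for this change in this assay.

For compound 4 the expected step is a 1.2-fold higher number from compound 3 to compound 4 (0.07 log units; within the scatter), that is, none beyond the scatter. Compound 4 is accordingly estimated at 3500 nM in this assay, with a range from 1500 nM to 8000 nM.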

Compound 4, inhibition constant: 4000 nM
Beside the measured number, compound 4's estimate is 1.1-fold (0.06 log units) below it; the range from low to high includes it.
By their numbers in this assay, from the lowest: compounds 3, 2, 4 and 1 (each within the scatter of the next).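

Methoxy in place of hydrogen on this aromatic carbon, ortho to a methoxy group, gives a 1.3-fold higher number from compound 3 to compound 4 (0.12 log units; within the scatter) in this assay, a direct reading showing that the 3,4,5-trimethoxyphenyl group is accommodated here without a move beyond the scatter. The wider changes also stay within the scatter: 3,4,5-trimethoxyphenyl in place of 4-chlorophenyl on the amine nitrogen gives no change at the digits printed from compound 2 to compound 4 (within the scatter), and ethynyl in place of hydrogen on the saturated chain carbon gives a 1.3-fold lower number from compound 1 to compound 4 (0.10 log units; within the scatter), so neither the aryl group nor the ethynyl-bearing chain on the nitrogen separates these compounds on this read-out. No supporting evidence bears on these readings.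

As far as these compounds go, it remains open whether a group of another kind at this ring position, such as a carboxylic acid or a primary amine, would produce a step beyond the scatter. A longer chain on the amine nitrogen, or a hydroxyl in place of one methoxy, also remains to be read against compound 4 on the shared core.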